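This account rests on a few compounds, and the source may have more. Where it says the series, first, only, none or still open, it means among the compounds named here.

Of the compounds shown here, two sharing one core have been measured in a functional assay on cells for agonist activity at Glucose-dependent insulinotropic receptor (Homo sapiens), read by HTRF and cAMP accumulation, with a stated time of 30 min; on this read-out lower numbers stand for an effect already at smaller amounts and higher numbers for an effect only at larger amounts of compound. Compound 1 `CC(C)OC(=O)N1CCC2(CC1)CC(CCCOc1ccc(C(N)=O)c(F)c1)C2` carries an amino group on the carbonyl carbon, and in this assay compound 1 gives 52 nM. Compound 2 `CC(C)OC(=O)N1CCC2(CC1)CC(CCCOc1ccc(C(=O)N3CCCC3)c(F)c1)C2` has pyrrolidin-1-yl in that place, and in this assay compound 2 gives 29 nM. The step of a 1.8-fold lower number from compound 1 to compound 2 (0.25 log units; within the scatter) is within the scatter, so on the numbers shown compound 2 and compound 1 cannot be set apart. Compound 3 `CC(C)OC(=O)N1CCC2(CC1)CC(CCCOc1ccc(C(=O)N3CCC3)c(F)c1)C2` differs from compound 2 in one place: azetidin-1-yl in place of pyrrolidin-1-yl on a carbonyl carbon. Among the measured compounds shown here, no measured step covers this shrinking of the ring; the only step known, a 1.8-fold lower number from compound 1 to compound 2 (0.25 log units; within the scatter), concerns a different change at the same carbonyl carbon. Because a 1.8-fold lower number from compound 1 to compound 2 (0.25 log units; within the scatter) stayed within the scatter, compound 3 is expected to show a step of a 1.2-fold higher number from compound 2 to compound 3 (0.08 log units; within the scatter), not beyond the scatter. The estimate for compound 3 in this assay is 35 nM, ranging from 15 nM to 80 nM.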

Compound 3, half-maximal effective concentration in the Glucose-dependent insulinotropic receptor assay: 34 nM
Beside the measured number, compound 3's estimate is 1.0-fold (0.01 log units) above it; the measured number falls inside the stated range.
By their numbers in the Glucose-dependent insulinotropic receptor assay, from the lowest: compounds 2, 3 and 1 (each within the scatter of the next).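

In the Glucose-dependent insulinotropic receptor assay compound 3 gives 34 nM, azetidin-1-yl in place of pyrrolidin-1-yl on the carbonyl carbon gives a 1.2-fold higher number from compound 2 to compound 3 (0.07 log units; within the scatter), and azetidin-1-yl in place of amino gives a 1.5-fold lower number from compound 1 to compound 3 (0.18 log units; within the scatter), so three different groups at this position now sit within the scatter of one another. In a physicochemical assay for solubility, read by HPLC, in phosphate buffer, with a stated time of 24 h, at pH 6.8 (a higher number here means a more soluble compound, a lower number a less soluble compound), compound 2 gives 3.85 ug/mL and compound 3 gives 3.43 ug/mL, and the same ring change gives a 1.1-fold lower number from compound 2 to compound 3 (0.05 log units; within the scatter), so neither read-out sets the two rings apart. Nothing at hand offers a reason for these results.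

Still open, on these data alone, is whether any group at this carbonyl carbon moves the numbers beyond the scatter, such as the larger piperidin-1-yl ring, a morpholin-4-yl ring with a second hetero atom, or an open-chain dimethylamino group. As far as these compounds go, all three compounds share the rest of the core, so the effect of a change elsewhere also remains unknown.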